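From 3,4-dichlorophenyl to 3,4-difluorophenyl on the shared core

The compounds below may be only part of what the source reports. "The series", "measured", "known", "first", "only" and "open" are said of these compounds alone.

In a toxicity assay on cells (Erythrocyte, Ovis aries) for cytotoxicity (on this read-out lower numbers stand for higher toxicity in this test and higher numbers for lower toxicity in this test), compound 1 `O=c1cc(C(F)(F)F)[nH]c2cc(C(F)(F)F)cc(Nc3ccc(C(F)(F)F)cn3)c12` gives > 32 ug/mL, which is a limit. Compound 2 `O=c1cc(C(F)(F)F)[nH]c2cc(C(F)(F)F)cc(Nc3ccc(Cl)c(Cl)c3)c12` gives > 32 ug/mL, also a limit, so it stands without a number. Going by the values given here, the one measured step is a step that the two limits leave unreadable from compound 1 to compound 2, so it sets no size. The evidence amounts to the limit of > 32 ug/mL in this assay, at which 2 of the 2 values shown sit. Compound 3 `O=c1cc(C(F)(F)F)[nH]c2cc(C(F)(F)F)cc(Nc3ccc(F)c(F)c3)c12` carries 3,4-difluorophenyl in place of 3,4-dichlorophenyl on a nitrogen on an aromatic ring. In this assay no step beyond the scatter and no direction is expected, and the estimated step is a step that the limit leaves unreadable from compound 2 to compound 3. Compound 3 is expected at 40 ug/mL. The estimated range runs from 20 ug/mL to 80 ug/mL.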

Compound 3, half-maximal cytotoxic concentration: > 32 ug/mL
Compound 3 was reported as a limit; the forecaster's own chance of this, stated with the estimate: 85%; the middle value lies beyond the limit too.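

In this assay compound 3 gives > 32 ug/mL, a limit, so the steps among compound 1, compound 2 and compound 3 cannot be read. The compounds shown leave open whether the aryl groups on the shared core differ in toxicity at all.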